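This account rests on a few compounds, and the source may have more. Where it says the series, first, only, none or still open, it means among the compounds named here.

Working notes on the series. Compound 1 `Cc1ccc(C2=NN(C(=S)Nc3ccccc3)C(c3ccc4c(c3)OCCO4)C2)cc1` carries a 4-methylphenyl on the carbon with a double bond to nitrogen of the shared core. In a functional assay on WM 266-4 cells (Homo sapiens) for antiproliferative activity, read by MTT assay, with a stated time of 48 h (a lower number here means a stronger inhibitor of growth, a higher number a weaker inhibitor of growth), compound 1 gives 10300 nM, the second highest of the three numbers in hand. Compound 2 `COc1cccc(C2=NN(C(=S)Nc3ccccc3)C(c3ccc4c(c3)OCCO4)C2)c1` gives 1380 nM, and compound 3 `Cc1ccc(C2=NN(C(=S)Nc3ccccc3)C(c3ccc4c(c3)OCCO4)C2)cc1C` gives 70500 nM. The steps at this position are a 7.5-fold lower number from compound 1 to compound 2 (0.87 log units; beyond the scatter), a 6.8-fold higher number from compound 1 to compound 3 (0.84 log units; beyond the scatter) and a 51-fold higher number from compound 2 to compound 3 (1.71 log units; beyond the scatter), so the group on this carbon moves the numbers well beyond the scatter in either direction. Compound 4 `S=C(Nc1ccccc1)N1N=C(c2cccs2)CC1c1ccc2c(c1)OCCO2` differs from compound 1 by thiophen-2-yl in place of 4-methylphenyl on a carbon with a double bond to nitrogen. Within the data shown here, no measured step tells what a thiophen-2-yl does here; a modest step is expected, direction uncertain, which for compound 4 means an estimate of 5000 nM in this assay, within 1000 nM to 25000 nM. That estimate corresponds to an expected step of a 2.1-fold lower number from compound 1 to compound 4 (0.31 log units; beyond the scatter).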

Compound 4, concentration for 50% growth inhibition: 154000 nM
Beside the measured number, compound 4's estimate is 31-fold (1.49 log units) below it; measured number outside the range, above it.
By their numbers in this assay, from the lowest: compound 2; then compound 1; then compound 3; then compound 4.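

Thiophen-2-yl gives the weakest inhibitor of growth of the four in this assay (a 15-fold higher number from compound 1 to compound 4 (1.17 log units; beyond the scatter); a 2.2-fold higher number from compound 3 to compound 4 (0.34 log units; beyond the scatter)). Among these compounds, the range at this position now widens (a 110-fold higher number from compound 2 to compound 4 (2.05 log units; beyond the scatter)), and this is the first five-membered aromatic ring with one hetero atom seen here, set against three six-membered aromatic rings of carbon only. Nothing available explains the loss. Open, from the compounds shown here alone, is whether furan-2-yl or pyridin-3-yl on this carbon would give a number closer to compound 2 or to compound 4.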